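Cytotoxicity limit and a changed amino group

The source may hold more compounds than are shown below. What is called first, only, known or untested is meant among the compounds shown, and "the series" means these compounds.

Measured in an ADME assay on Vero cells (Chlorocebus sabaeus) for cytotoxicity, with a stated time of 5 days; a lower number here means a stronger inhibitor, a higher number a weaker inhibitor:
Compound 1 `CC(C)(CO)Nc1nc(N)nc2c1ncn2[C@H]1C[C@H](N=[N+]=[N-])[C@@H](CO)O1`: > 100000 nM, a limit
Compound 2 `[N-]=[N+]=N[C@H]1C[C@H](n2cnc3c(NC4CC4)nc(N)nc32)O[C@@H]1CO`: > 100000 nM, a limit

Compound 2 has no number, only a limit, and the same holds across the series: the limit of > 100000 nM in this assay, at which 2 of the 2 values shown sit. Going by the values given here, the only measured step is a step that the two limits leave unreadable from compound 1 to compound 2, so it gives no size to carry over. Compound 3 `C=CCN(C)c1nc(N)nc2c1ncn2[C@H]1C[C@H](N=[N+]=[N-])[C@@H](CO)O1` differs from compound 2 by one change: allyl(methyl)amino in place of cyclopropylamino on an aromatic carbon. No step beyond the scatter is expected in this assay, and no direction can be given. The estimated step is a number no higher from compound 2 to compound 3 (the limit leaves the size open). Compound 3 is expected at 100000 nM, within an estimated range of 40000 nM to 200000 nM, and will probably be reported as a limit again.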

Compound 3, half-maximal inhibitory concentration: 32000 nM
The estimate for compound 3 lay 3.1-fold (0.49 log units) above the measured number; measured number below the stated range.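

In this assay, the substituent on this aromatic carbon proves able to move the read-out off the limit: allyl(methyl)amino, with no ring and no hydrogen-bond donor, gives an at least 3.1-fold lower number from compound 2 to compound 3 (0.49 log units; beyond the scatter) and an at least 3.1-fold lower number from compound 1 to compound 3 (0.49 log units; beyond the scatter). Both steps start from a limit, so each gives only the smallest possible size. Compound 1 and compound 2 offer no number to set beside compound 3: the limit of > 100000 nM in this assay, at which 2 of the 3 values shown sit.

The compounds shown leave open whether the double bond or the methyl on the nitrogen goes with the step. Dimethylamino or propyl(methyl)amino on this carbon would separate the two.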